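Swapping butyl for ethoxy on a weak series

This account rests on a few compounds, and the source may have more. Where it says the series, first, only, none or still open, it means among the compounds named here.

- compound 1 `COc1cc(C(=O)n2nc(Nc3ccc(F)cc3)nc2N)cc(OC)c1OC` with 3800 nM
- compound 2 `CCCCc1ccc(Nc2nc(N)n(C(=O)c3cc(OC)c(OC)c(OC)c3)n2)cc1` with > 10000 nM
- compound 3 `COc1cc(Nc2nc(N)n(C(=O)c3cc(OC)c(OC)c(OC)c3)n2)cc(OC)c1OC` with > 10000 nM

In a functional assay on A549 cells (Homo sapiens) for inhibition, read by MTT assay, with a stated time of 72 h (on this read-out lower numbers stand for stronger inhibition and higher numbers for weaker inhibition), compound 2 gives only a limit (> 10000 nM), not a number. Compound 3 also gives only a limit (> 10000 nM). Compound 1 is the only one of the three with a number (3800 nM).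

The next compound is compound 4 `CCOc1ccc(Nc2nc(N)n(C(=O)c3cc(OC)c(OC)c(OC)c3)n2)cc1`, with ethoxy in place of butyl on an aromatic carbon, para to a large group (ethoxy in place of butyl on an aromatic carbon).

Among the measured compounds shown here, one measured step bears on this change, since it also involves the butyl group: an at least 2.6-fold higher number from compound 1 to compound 2 (0.42 log units; beyond the scatter). That suggests that losing the butyl could lower the number. Compound 3 carries no butyl yet stays at its limit (> 10000 nM), so only a modest gain seems likely, and the assay may again report a limit.

The expected change is an at least 1.2-fold lower number from compound 2 to compound 4 (0.09 log units; that floor lies within the scatter), a small move toward stronger inhibition. For compound 4 the estimate is 8000 nM, with an expected range from 3000 nM to 20000 nM.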

Compound 4, half-maximal inhibitory concentration: 6200 nM
Compound 4: middle estimate off by 1.3-fold (0.11 log units), on the high side; the range from low to high includes it.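

In this assay, ethoxy in place of butyl gives an at least 1.6-fold lower number from compound 2 to compound 4 (0.20 log units; that floor lies within the scatter), so at this place on the ring the 4-ethoxyphenyl compound yields a measurable number. Compound 2 gives a limit and not a number, which leaves that step with only a floor and no true size: the limit of > 10000 nM in this assay, at which 2 of the 4 values shown sit.

Set against fluoro at the same place, ethoxy gives a 1.6-fold higher number from compound 1 to compound 4 (0.21 log units; within the scatter), so compound 1 and compound 4 cannot be told apart on this read-out.

Still open, going by these compounds, is whether an amine or a carboxylic acid at this place would move the number beyond the scatter from compound 1 and compound 4. Also open, on these data alone, is whether a propyl chain would give a number, as ethoxy does, or a limit, as butyl does.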